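Cinnamamide in place of indolecarboxamide on the bis-indole core

The compounds below may be only part of what the source reports. "The series", "measured", "known", "first", "only" and "open" are said of these compounds alone.

For the measured compounds named here, compound 2 `CN1[C@@H]2c3[nH]c4ccccc4c3C[C@H]1[C@H](C#N)N1[C@@H](CNC(=O)c3cc4ccccc4[nH]3)c3[nH]c4ccccc4c3C[C@@H]21` gives 7100 nM in a functional assay on A2780 cells (Homo sapiens) for cytotoxicity, read by MTT assay, with a stated time of 72 h (on this read-out lower numbers stand for stronger inhibition and higher numbers for weaker inhibition), the highest of the two numbers so far. Going by the values given here, its only measured neighbour, compound 1 `CN1[C@@H]2c3[nH]c4ccccc4c3C[C@H]1[C@H](C#N)N1[C@@H](CNC(=O)c3ccc(F)cc3)c3[nH]c4ccccc4c3C[C@@H]21`, gives 250 nM in this assay; the sole step available is a 28-fold higher number from compound 1 to compound 2 (1.45 log units; beyond the scatter), which shows the indole amide carrying the weaker number of the pair. Compound 3 `COc1ccc(/C=C/C(=O)NC[C@H]2c3[nH]c4ccccc4c3C[C@H]3[C@H]4c5[nH]c6ccccc6c5C[C@@H]([C@H](C#N)N23)N4C)cc1` differs from compound 2 in one place: 2-(4-methoxyphenyl)ethenyl in place of 1H-indol-2-yl on a carbonyl carbon. Among the compounds with values here, no measured step covers this exchange directly; the only bearing step is the one from compound 1 to compound 2, which shows that the amide substituent can move this read-out by a large amount and that the indole variant sits at the weak end. On that basis a step toward a lower number is expected, a 4.7-fold lower number from compound 2 to compound 3 (0.68 log units; beyond the scatter), though with wide uncertainty. Compound 3 is estimated at 1500 nM in this assay, with a range from 300 nM to 7500 nM.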

Compound 3, half-maximal inhibitory concentration: 860 nM
Compound 3: the middle estimate sits 1.7-fold (0.24 log units) above what was measured; measured number inside the range.
By their numbers in this assay, from the lowest: compound 1; then compound 3; then compound 2.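

Exchanging 1H-indol-2-yl for 2-(4-methoxyphenyl)ethenyl on the carbonyl carbon in this assay gives an 8.3-fold lower number from compound 2 to compound 3 (0.92 log units; beyond the scatter), so the amide position tolerates a group without the indole's ring pair, and the weak number of compound 2 does not extend to every large substituent here. The same group does not match 4-fluorophenyl, with a 3.4-fold higher number from compound 1 to compound 3 (0.54 log units; beyond the scatter), which leaves compound 1 with the lowest number of the three. No supporting data on these compounds explain either step.

The entering group differs from 4-fluorophenyl in both its double bond and its methoxy, and the compounds shown do not separate these two changes. From the compounds shown here alone, a plain 2-phenylethenyl group, or an aminomethyl or carboxylic acid substituent on the phenyl ring, remains open at this position.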